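This account rests on a few compounds, and the source may have more. Where it says the series, first, only, none or still open, it means among the compounds named here.

Measured compounds: compound 1 `COC(=O)C1=C(C)NC(=O)NC1c1ccoc1`, compound 2 `CCCOC(=O)C1=C(C)NC(=O)NC1c1ccoc1`, and compound 3 `CCCOC(=O)C1=C(C)NC(=O)NC1c1cccs1`. In an assay on membranes from CHO cells for displacement of a labelled ligand from adenosine receptor A1 (Homo sapiens), read by scintillation counting, with a stated time of 60 min, tested at 1 uM (a lower number here means less inhibition, a higher number more inhibition at the concentration tested (going by the name of the read-out)), compound 1 gives 8%, compound 2 gives 50%, and compound 3 gives 43%.

Compound 3 stands second highest of the three numbers; its nearest neighbour is compound 2, and that gap lies within the scatter, while compound 1 sits well below it. Compound 4 `CC1=C(C(=O)OCc2ccccc2)C(c2cccs2)NC(=O)N1` differs from compound 3 by phenyl in place of ethyl on a saturated chain carbon bound to an oxygen next to a carbonyl group. Among the compounds with values here, two measured steps bear on this. The step of a number 42 percentage points higher from compound 1 to compound 2 (beyond the scatter) sits at the same place and was large. The step of a number 7 percentage points lower from compound 2 to compound 3 (within the scatter) concerns the ring and stayed within the scatter. On these data alone, because of the large rise in a number 42 percentage points higher from compound 1 to compound 2 (beyond the scatter) a further change at that place is expected to hold or raise the read-out, but the move from propyl to benzyl is untested, so only a modest step is expected: a number 9 percentage points higher from compound 3 to compound 4 (within the scatter). Compound 4 is estimated at 52%, with a range from 30% to 74%.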

Compound 4, a percentage reported as inhibition, at one concentration (the size of the read-out at that concentration, not a potency): 45%
Beside the measured number, compound 4's estimate is 7 percentage points above it; measured number inside the range.
By their numbers in this assay, from the lowest: compound 1; then compounds 3, 4 and 2 (each within the scatter of the next).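

In this assay, phenyl in place of ethyl on a saturated chain carbon bound to an oxygen next to a carbonyl group, read as propyl to benzyl, gives a number 2 percentage points higher from compound 3 to compound 4 (within the scatter). Within the data shown here, this place, so far seen only in the larger step from hydrogen to ethyl, can therefore also carry a six-membered aromatic ring of carbon only, with compound 3 and compound 4 level within the scatter. No available evidence accounts for this result.

On these data alone, it remains open how a longer chain or an amine at this place would read. As far as these compounds go, whether benzyl reads the same with furan-3-yl on the ring also remains open.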